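Extending a Methyl to a Benzyl on a Diaryl Ether

A few compounds are considered here, and "the series" means these few. Any claim that something is new, unique, unknown or untested is made for them only; others in the source may bear on it.

Compound 2 `Cc1cccc(Oc2ccc(N3C[C@@H](C(F)(F)F)C[C@H]3CC(=O)O)cc2)c1C` carries a 2,3-dimethylphenyl on the ether oxygen, and in a functional assay on cells for agonist activity at Free fatty acid receptor 1 (Homo sapiens), read by FLIPR and calcium flux, with a stated time of 100 s (on this read-out lower numbers stand for an effect already at smaller amounts and higher numbers for an effect only at larger amounts of compound), compound 2 gives 110 nM. This is the highest of the three numbers in hand, though the gaps stay inside the scatter: compound 1 `COc1ccc(Oc2ccc(N3C[C@@H](C(F)(F)F)C[C@H]3CC(=O)O)cc2)c(C)c1` gives 55 nM, and compound 3 `Cc1cccc(C)c1Oc1ccc(N2C[C@@H](C(F)(F)F)C[C@H]2CC(=O)O)cc1` gives 82 nM. The steps of a 2.0-fold higher number from compound 1 to compound 2 (0.30 log units; within the scatter) and a 1.3-fold lower number from compound 2 to compound 3 (0.13 log units; within the scatter) both lie within the scatter, as does a 1.5-fold higher number from compound 1 to compound 3 (0.17 log units; within the scatter).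

Compound 4 `COc1ccc(F)c(Cc2cccc(Oc3ccc(N4C[C@@H](C(F)(F)F)C[C@H]4CC(=O)O)cc3)c2C)c1` differs from compound 2 by 2-fluoro-5-methoxyphenyl in place of hydrogen on a saturated chain carbon bound to an aromatic carbon; cut one bond further out, the change reads methyl to 2-fluoro-5-methoxybenzyl. Going by the values given here, none of the measured steps involves an addition of this kind; they only exchange small substituents on the aryl ether, and all of them stayed within the scatter. There is thus no measured basis for a step in either direction, so the estimate rests on the value of compound 2 with a wide range. Compound 4 is expected to give 100 nM (range 20 nM to 500 nM). The expected step is a 1.1-fold lower number from compound 2 to compound 4 (0.04 log units; within the scatter), none beyond the scatter.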

Compound 4, half-maximal effective concentration: 500 nM
Estimate against measurement, compound 4: 5.0-fold (0.70 log units) below; measured number inside the range.
By their numbers in this assay, from the lowest: compounds 1, 3 and 2 (each within the scatter of the next); then compound 4.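

Methyl to 2-fluoro-5-methoxybenzyl is the first change here that moves the number in this assay beyond the scatter, with a 4.5-fold higher number from compound 2 to compound 4 (0.66 log units; beyond the scatter). Going by these compounds alone, the exchanges of small substituents among compounds 1, 2 and 3 gave no such separation, so the saturated chain carbon bound to an aromatic carbon is the first place in this set where a change clearly registers, and it registers as a higher number. No measurement at hand bears on why the number rises.

From the compounds shown here alone, whether the rise comes with the added ring itself or with any extension at this carbon stays open. An ethyl, a longer chain or an unsubstituted benzyl would help to separate the two, as would a benzyl carrying an amine or a carboxylic acid.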